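Capping the Indole Nitrogen of Compound 3

The source may report more compounds than this note shows. Statements on the series, on what has been measured and on what is new or still open speak of the compounds shown alone.

The measured compounds:
Compound 1, `COc1cc(-c2ccnc3cc(-c4ccc(C(C)(C)C)cc4)nn23)cc(OC)c1OC`, gives in a functional assay on MCF7 cells (Homo sapiens) for inhibition, read by CCK-8 assay, with a stated time of 48 h (on this read-out higher numbers stand for weaker inhibition and lower numbers for stronger inhibition), only a limit, > 10000 nM.
Compound 2, `COc1cc(-c2ccnc3cc(-c4ccc(C(C)=O)cc4)nn23)cc(OC)c1OC`, gives in this assay a value of 5230 nM.
Compound 3, `COc1cc(-c2ccnc3cc(-c4c[nH]c5ccccc45)nn23)cc(OC)c1OC`, gives in this assay a value of 85 nM.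

Compound 3 stands lowest of the two numbers given; its nearest neighbour is compound 2, and the step of a 62-fold lower number from compound 2 to compound 3 (1.79 log units; beyond the scatter) is beyond the scatter, so compound 3 is the most potent of the three. The step of an at least 110-fold lower number from compound 1 to compound 3 (2.07 log units; beyond the scatter) is also large, although it starts from a limit (the limit of > 10000 nM in this assay, at which 1 of the 3 values shown sits). The remaining step, an at least 1.9-fold lower number from compound 1 to compound 2 (0.28 log units; that floor lies within the scatter), has a floor that lies within the scatter.

Compound 4, `COc1cc(-c2ccnc3cc(-c4cn(C(=O)OC(C)(C)C)c5ccccc45)nn23)cc(OC)c1OC`, differs from compound 3 in one place: tert-butoxycarbonyl in place of hydrogen on an aromatic nitrogen. Going by the values given here, no measured step touches the aromatic nitrogen of the indole, so none bears directly on this change; the two steps into compound 3 show only that the 1H-indol-3-yl group carries the gain over the 4-(tert-butyl)phenyl and 4-acetylphenyl groups. The size of the step in this assay is therefore open. A modest rise in the number is expected for compound 4, a 4.7-fold higher number from compound 3 to compound 4 (0.67 log units; beyond the scatter). Compound 4 is estimated at 400 nM, with a range from 80 nM to 3000 nM.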

Compound 4, half-maximal inhibitory concentration: 268 nM
For compound 4 the middle estimate is 1.5-fold (0.17 log units) above the measured one, and the stated range covers the measured number.
By their numbers in this assay, from the lowest: compound 3; then compound 4; then compound 2. At a limit, above all of these: compound 1.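

Placing tert-butoxycarbonyl on the aromatic nitrogen of the indole, in place of hydrogen, gives a 3.2-fold higher number from compound 3 to compound 4 (0.50 log units; beyond the scatter) in this assay, so this position tolerates a large group with only a modest loss. The earlier steps shown here replaced the whole group on the core and left this nitrogen untouched; this step shows that the hydrogen on it is not needed to keep most of the gain of the 1H-indol-3-yl group, since compound 4, which lacks that hydrogen, still gives 268 nM. Nothing measured here accounts for the size of the step.

The compounds shown do not separate the loss of the hydrogen from the arrival of the tert-butoxycarbonyl group, as only this one group sits on the nitrogen. As far as these compounds go, how a methyl group, an acetyl group or a longer chain ending in an amine would read at this position in this assay remains open.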